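Pyrrolidine for Dimethylamino on the Hydroxymethyl Analogue

A few compounds are considered here, and "the series" means these few. Any claim that something is new, unique, unknown or untested is made for them only; others in the source may bear on it.

Compound 1 `CN(C)c1ccc(-c2nc3c(s2)C(O)CNC3)cc1`: in a functional assay on MCF-10A cells (Homo sapiens) for cytotoxicity, read by sulforhodamine B assay, with a stated time of 2 days (a lower number here means a stronger inhibitor, a higher number a weaker inhibitor), compound 1 gives 70200 nM.
Compound 2 `OC1CNCc2nc(-c3ccc(N4CCCC4)cc3)sc21`: in this assay compound 2 gives 27800 nM.
Compound 3 `CN(C)c1ccc(-c2nc3c(s2)C(O)CNC3)c(CO)c1`: in this assay compound 3 gives 70000 nM.

Among these three numbers compound 3 stands second highest; compound 1 lies within the scatter of it, while compound 2 shows a lower number that lies beyond the scatter.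

Compound 4 `OCc1cc(N2CCCC2)ccc1-c1nc2c(s1)C(O)CNC2` differs from compound 3 by pyrrolidin-1-yl in place of dimethylamino on an aromatic carbon. Among the measured compounds shown here, two measured steps bear on this. The same exchange on the shared core without the hydroxymethyl group gave a 2.5-fold lower number from compound 1 to compound 2 (0.40 log units; beyond the scatter), and adding the hydroxymethyl group gave a 1.0-fold lower number from compound 1 to compound 3 (0.00 log units; within the scatter), so the hydroxymethyl group seems not to disturb the effect. A modest lowering of similar size is therefore expected in this assay, that is a 2.5-fold lower number from compound 3 to compound 4 (0.40 log units; beyond the scatter) is expected. Compound 4 is estimated at 28000 nM, with a range from 12000 nM to 60000 nM.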

Compound 4, half-maximal inhibitory concentration: > 100000 nM
Compound 4 was reported as a limit (the forecaster's own chance of this, stated with the estimate: 5%); at least 3.5-fold (0.55 log units) between middle value and limit.
By their numbers in this assay, from the lowest: compound 2; then compounds 3 and 1 (each within the scatter of the next). At a limit, above all of these: compound 4.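

With compound 4 standing only as a limit, the pyrrolidin-1-yl exchange gives an at least 1.4-fold higher number from compound 3 to compound 4 (0.15 log units; that floor lies within the scatter), so the lowering seen without the hydroxymethyl group does not carry over to the core that bears it: the same change on two cores in this assay, a 2.5-fold lower number (0.40 log units; beyond the scatter) from compound 1 to compound 2 and an at least 1.4-fold higher number (0.15 log units; that floor lies within the scatter) from compound 3 to compound 4, at least 3.6-fold (0.55 log units) apart, beyond the scatter of two such steps

The hydroxymethyl group's step also depends on the amine at the other position, with an at least 3.5-fold higher number from compound 2 to compound 4 (0.55 log units; beyond the scatter): the same change on two cores in this assay, a 1.0-fold lower number (0.00 log units; within the scatter) from compound 1 to compound 3 and an at least 3.5-fold higher number (0.55 log units; beyond the scatter) from compound 2 to compound 4, at least 3.6-fold (0.55 log units) apart, beyond the scatter of two such steps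

From the compounds shown here alone, how far compound 4 lies beyond its limit stays open, as does whether a piperidine in place of pyrrolidin-1-yl, or a carboxylic acid in place of hydroxymethyl, would follow the same course.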